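This account rests on a few compounds, and the source may have more. Where it says the series, first, only, none or still open, it means among the compounds named here.

Three related compounds have been tested in a functional assay on HeLa cells (Homo sapiens) for cytotoxicity, read by MTT assay, with a stated time of 48 h; a lower number here means a stronger inhibitor, a higher number a weaker inhibitor. Compound 1 `O=C(/C=C/c1cccc(F)c1)Nc1ccc(CC2=CC(=O)OC2)cc1` gives 49000 nM in this assay. Compound 2 `C=C1OC(=O)C=C1Cc1ccc(NC(=O)/C=C/c2cccc(F)c2)cc1` differs from compound 1 by a group of 7 heavy atoms (5 carbon, 2 oxygen; one five-membered non-aromatic ring with 1 hetero atom) in place of a group of 6 heavy atoms (4 carbon, 2 oxygen; one five-membered non-aromatic ring with 1 hetero atom), on a saturated chain carbon bound to an aromatic carbon, and in this assay compound 2 gives 30200 nM; that move is a 1.6-fold lower number from compound 1 to compound 2 (0.21 log units; within the scatter). Compound 3 `O=C(/C=C/c1ccc(F)cc1)Nc1ccc(CC2=CC(=O)OC2)cc1` differs from compound 1 by 4-fluorophenyl in place of 3-fluorophenyl on a double-bonded chain carbon bound to a double-bonded chain carbon. For compound 3 this assay reports only a limit, > 50000 nM, which is the boundary described by the limit of > 50000 nM in this assay, at which 1 of the 3 values shown sits. The move from compound 1 to compound 3 is therefore known only as an at least 1.0-fold higher number from compound 1 to compound 3 (0.00 log units; that floor lies within the scatter).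

Compound 4 `C=C1OC(=O)C=C1Cc1ccc(NC(=O)/C=C/c2ccc(F)cc2)cc1` has not yet been measured in this assay. It differs from compound 3 by a group of 7 heavy atoms (5 carbon, 2 oxygen; one five-membered non-aromatic ring with 1 hetero atom) in place of a group of 6 heavy atoms (4 carbon, 2 oxygen; one five-membered non-aromatic ring with 1 hetero atom), on a saturated chain carbon bound to an aromatic carbon, the same change that separates compound 1 from compound 2, made on the same place; the two cores differ as described by 4-fluorophenyl in place of 3-fluorophenyl on a double-bonded chain carbon bound to a double-bonded chain carbon. The step from compound 3 to compound 4 is expected to be an at least 1.1-fold lower number from compound 3 to compound 4 (0.04 log units; that floor lies within the scatter), resting on the measured step of a 1.6-fold lower number from compound 1 to compound 2 (0.21 log units; within the scatter) and on compound 3 standing at the limit > 50000 nM. On that basis compound 4 is estimated to give about 45000 nM in this assay, plausibly between 25000 nM and 90000 nM.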

Compound 4, half-maximal inhibitory concentration: 2770 nM
For compound 4 the middle estimate is 16-fold (1.21 log units) above the measured one, outside the stated range (below it).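

In this assay, from the compounds shown here alone, the exchange of ring groups on the saturated chain carbon gives an at least 18-fold lower number from compound 3 to compound 4 (1.25 log units; beyond the scatter), a step that does not match the same exchange on the other core: the same change on two cores in this assay, a 1.6-fold lower number (0.21 log units; within the scatter) from compound 1 to compound 2 and an at least 18-fold lower number (1.25 log units; beyond the scatter) from compound 3 to compound 4, at least 11-fold (1.04 log units) apart, beyond the scatter of two such steps Likewise, 4-fluorophenyl in place of 3-fluorophenyl gives an 11-fold lower number from compound 2 to compound 4 (1.04 log units; beyond the scatter), so the two changes do not simply add up in these four compounds: the same change on two cores in this assay, an at least 1.0-fold higher number (0.00 log units; that floor lies within the scatter) from compound 1 to compound 3 and an 11-fold lower number (1.04 log units; beyond the scatter) from compound 2 to compound 4, at least 11-fold (1.04 log units) apart, beyond the scatter of two such steps Compound 3 stands only at a limit, > 50000 nM, so the true size of its step is unknown, and this single pair of cores shows that the ring exchange does not carry over at a fixed size, not why it differs or whether the same holds elsewhere.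

Going by these compounds, it remains open whether a chlorophenyl or methoxyphenyl group in place of the fluorophenyl group would give the same large step. On these data alone, it also remains open whether the extra double bond of the entering group is what matters, a question that a ring carrying a methyl group instead could address.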